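Naphthalene at the Sulfonyl Sulfur: Expecting a Weaker Number

This account rests on a few compounds, and the source may have more. Where it says the series, first, only, none or still open, it means among the compounds named here.

Three compounds share one core and differ only in the ring attached to the sulfonyl sulfur. Compound 1 `COc1cc(-c2nc(-c3ccccc3)[nH]c2-c2ccnc(NCCCNS(=O)(=O)c3ccccc3)n2)ccc1Cl` carries a plain phenyl there and, in a functional assay on LOX IMVI cells (Homo sapiens) for cytotoxicity, read by MTT assay, with a stated time of 24 h (on this read-out higher numbers stand for weaker inhibition and lower numbers for stronger inhibition), compound 1 gives 7470 nM. Compound 2 `COc1cc(-c2nc(-c3ccccc3)[nH]c2-c2ccnc(NCCCNS(=O)(=O)c3ccc(Cl)cc3)n2)ccc1Cl` gives 60900 nM in this assay, a step of an 8.2-fold higher number from compound 1 to compound 2 (0.91 log units; beyond the scatter). Compound 3 `COc1cc(-c2nc(-c3ccccc3)[nH]c2-c2ccnc(NCCCNS(=O)(=O)c3cccc(F)c3)n2)ccc1Cl` gives 5110 nM in this assay; the step of a 1.5-fold lower number from compound 1 to compound 3 (0.16 log units; within the scatter) means compound 3 and compound 1 cannot be told apart, while a 12-fold lower number from compound 2 to compound 3 (1.08 log units; beyond the scatter) sets compound 3 clearly apart from compound 2.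

Compound 4 `COc1cc(-c2nc(-c3ccccc3)[nH]c2-c2ccnc(NCCCNS(=O)(=O)c3cccc4ccccc34)n2)ccc1Cl` changes the same ring again: naphthalen-1-yl in place of 3-fluorophenyl on a sulfonyl sulfur. Among the compounds with values here, the steps that bear on this are those that altered the ring on the sulfonyl sulfur. A hydrogen-to-fluoro change left the number unchanged, but a hydrogen-to-chloro change raised it by an 8.2-fold higher number from compound 1 to compound 2 (0.91 log units; beyond the scatter). Naphthalen-1-yl enters more atoms than either, so for compound 4 a modestly higher number is expected in this assay, roughly a 2.3-fold higher number from compound 3 to compound 4 (0.37 log units; beyond the scatter). The estimate for compound 4 is 12000 nM, with a range from 3000 nM to 50000 nM.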

Compound 4, half-maximal inhibitory concentration: 13500 nM
Beside the measured number, compound 4's estimate is 1.1-fold (0.05 log units) below it, within the range that was stated.
By their numbers in this assay, from the lowest: compounds 3, 1 and 4 (each within the scatter of the next, the first and the last beyond it); then compound 2.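

In this assay, naphthalen-1-yl on the sulfonyl sulfur, with its two six-membered aromatic rings, cannot be told apart from the plain phenyl, since a 1.8-fold higher number from compound 1 to compound 4 (0.26 log units; within the scatter) stays inside the usual variation between repeats. Adding atoms to this ring therefore does not by itself lead to a number as high as that of compound 2, as a 4.5-fold lower number from compound 2 to compound 4 (0.65 log units; beyond the scatter) shows for naphthalen-1-yl against 4-chlorophenyl. The comparison with 3-fluorophenyl does reveal a real but modest difference, a 2.6-fold higher number from compound 3 to compound 4 (0.42 log units; beyond the scatter), so compound 2 remains the clear outlier among the four.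

No measurement here explains why these ring changes have these effects. Going by these compounds, whether an amine or a carboxylic acid on this ring would move the number in either direction stays open, as does whether naphthalen-2-yl would match naphthalen-1-yl.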